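Methyl-to-hydrogen step on the aryl ketone of compound 1

This account rests on a few compounds, and the source may have more. Where it says the series, first, only, none or still open, it means among the compounds named here.

Measured so far:
compound 1 `COc1cc(OC)c(OC)cc1/C=C/C(=O)c1ccc(C)cc1`: 81100 nM
compound 2 `COc1cc(OC)c(OC)cc1/C=C/C(=O)c1cc(OC(C)=O)ccc1OC(C)=O`: 78500 nM
compound 3 `COc1cc(OC)c(-c2cc(=O)c3cc(Cl)ccc3o2)cc1OC`: > 150000 nM

In a functional assay on SW982 cells (Homo sapiens) for inhibition, read by MTT assay, with a stated time of 72 h (a higher number here means a weaker inhibitor, a lower number a stronger inhibitor), compound 1 gives 81100 nM. Compound 2 gives 78500 nM, and the two numbers lie within the usual scatter of each other, so no order between them is claimed. For compound 3 the assay reports only a limit, (the limit of > 150000 nM in this assay, at which 1 of the 3 values shown sits), not a number.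

Compound 4 `COc1cc(OC)c(OC)cc1/C=C/C(=O)c1ccccc1` is not yet measured. It differs from compound 1 in one place: hydrogen in place of methyl on an aromatic carbon. Within the data shown here, no measured pair shows a change of this kind, so the size of the step rests on the change alone. A small step is expected, a 1.1-fold higher number from compound 1 to compound 4 (0.05 log units; within the scatter), not beyond the scatter in either direction. Compound 4 is therefore expected to give 90000 nM, between 40000 nM and 150000 nM.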

Compound 4, half-maximal inhibitory concentration: > 150000 nM
Compound 4: only a limit was reported (the forecaster's own chance of this, stated with the estimate: 25%); middle value at least 1.6-fold (0.22 log units) from the limit.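

Hydrogen in place of methyl on an aromatic carbon gives an at least 1.8-fold higher number from compound 1 to compound 4 (0.26 log units; that floor lies within the scatter), the first reading of this change at this position in this assay. Only a floor can be stated for the step, so a loss of inhibition beyond the scatter is possible but not established. Compound 4 gives a limit, not a number, as does compound 3: the limit of > 150000 nM in this assay, at which 2 of the 4 values shown sit.

Going by these compounds, the true size of the step from methyl to hydrogen stays open. So does the effect of an amine or a carboxylic acid on this same aromatic carbon.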